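The compounds below may be only part of what the source reports. "The series", "measured", "known", "first", "only" and "open" are said of these compounds alone.

The measured compounds:
Compound 1, `Clc1cccc(Cn2ccc3nc(-c4ccccc4)nc-3c2)c1`: in an ADME assay on MDBK cells (Bos taurus) for cytotoxicity (on this read-out lower numbers stand for higher toxicity in this test and higher numbers for lower toxicity in this test), compound 1 gives > 100000 nM, which is a limit of the test and not a number.
Compound 2, `c1ccc(-c2nc3cc[nH]cc-3n2)cc1`: in this assay compound 2 gives > 100000 nM, again a limit and not a number.

Compound 2 thus stands at the upper edge of what this assay can report, and it does not stand alone there: both values in this set sit at the limit of > 100000 nM in this assay, at which 2 of the 2 values shown sit. Among the measured compounds shown here, no step between measured compounds can be read from these data, so nothing in this assay has yet been seen to move.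

Compound 3, `Clc1ccc(Cn2ccc3nc(-c4ccccc4)nc-3c2)s1`, has not been measured. It differs from compound 2 in one place: (5-chlorothiophen-2-yl)methyl in place of hydrogen on an aromatic nitrogen. Compound 1 also carries a substituent on the shared core and its value shows the same limit.

For the measured compounds named here, because every value so far sits at the limit of > 100000 nM in this assay, at which 2 of the 2 values shown sit, compound 3 is expected to show no change beyond the scatter, a number no higher from compound 2 to compound 3 (the limit leaves the size open). Compound 3 is estimated at 100000 nM, with a range from 30000 nM to 300000 nM, and the assay is expected most likely to report only its limit again.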

Compound 3, half-maximal cytotoxic concentration: > 100000 nM
Compound 3 was reported as a limit; the forecaster's own chance of this, stated with the estimate: 75%; the middle value sits exactly at the limit.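

In this assay compound 3 gives > 100000 nM, which is a limit and not a number. No step from compound 1 or compound 2 to compound 3 can be read, because all the values share one edge: the limit of > 100000 nM in this assay, at which 3 of the 3 values shown sit.

The compounds shown leave open how far the true values lie beyond that limit, and whether any group on the aromatic nitrogen would bring a readable number in this assay.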